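Sulfonyl aryl exchange on the shared core of compound 1

A few compounds are considered here, and "the series" means these few. Any claim that something is new, unique, unknown or untested is made for them only; others in the source may bear on it.

Three compounds of this series carry numbers in a functional assay on DU-145 cells (Homo sapiens) for inhibition, read by trypan blue exclusion, with a stated time of 72 h; on this read-out higher numbers stand for weaker inhibition and lower numbers for stronger inhibition. Compound 1, `Cn1c(=O)c(S(=O)(=O)c2ccc(F)cc2[N+](=O)[O-])cc2cnc(Nc3ccc4[nH]ccc4c3)nc21`, gives 1500 nM, the lowest of the three. Compound 2, `CN1CCN(c2ccc(Nc3ncc4cc(S(=O)(=O)c5ccc(F)cc5F)c(=O)n(C)c4n3)cc2)CC1`, gives 5000 nM, and compound 3, `Cn1c(=O)c(S(=O)(=O)c2ccccc2)cc2cnc(Nc3ccc4ncccc4c3)nc21`, gives 50000 nM; both gaps from compound 1 are beyond the scatter, so compound 1 stands as the strongest inhibitor among the measured set. Among the compounds with values here, compounds 2 and 3 differ from compound 1 in more than one place, so no single step between measured compounds can be read off.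

Compound 4, `COc1ccc(S(=O)(=O)c2cc3cnc(Nc4ccc5[nH]ccc5c4)nc3n(C)c2=O)cc1`, is unmeasured. It differs from compound 1 by 4-methoxyphenyl in place of 4-fluoro-2-nitrophenyl on a sulfonyl sulfur. Within the data shown here, the only measured compounds with a different group on the sulfonyl sulfur, compound 2 and compound 3, also carry other changes, so the effect of this exchange alone has no direct precedent here. The step from compound 1 is expected to run toward weaker inhibition, estimated as a 3.3-fold higher number from compound 1 to compound 4 (0.52 log units; beyond the scatter). For compound 4 the value in this assay is estimated at 5000 nM, within a range from 1000 nM to 25000 nM.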

Compound 4, half-maximal inhibitory concentration: 500 nM
Compound 4: the middle estimate sits 10-fold (1.00 log units) above what was measured; the measured number lies below the stated range.
By their numbers in this assay, from the lowest: compound 4; then compound 1; then compound 2; then compound 3.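

In this assay, the sulfonyl sulfur now has its first comparison that differs in one place only: 4-methoxyphenyl in place of 4-fluoro-2-nitrophenyl gives a 3.0-fold lower number from compound 1 to compound 4 (0.48 log units; beyond the scatter). The step is modest but beyond the scatter, and it shows that inhibition on these cells at this position does not depend on keeping the nitro and fluoro groups of compound 1. Nothing available explains why the number falls with this exchange.

This exchange removes the nitro and fluoro groups and adds the methoxy group in one step, which leaves the contribution of each group unresolved. Also open, on these data alone, is whether an ethoxy group, a dimethylamino group or a carboxylic acid in place of the methoxy group would hold the number of compound 4 or lose it.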